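Solubility notes on the fused-core series: compound 4

This account rests on a few compounds, and the source may have more. Where it says the series, first, only, none or still open, it means among the compounds named here.

Measured compounds:
Compound 1 `Cc1cc(NCc2cnccn2)n2nc(C)c(-c3ccccc3)c2n1`: 7100 nM
Compound 2 `COc1ccc(-c2c(C)nn3c(NCc4ccccn4)cc(C)nc23)cc1`: < 5000 nM
Compound 3 `COc1ccc(-c2cnn3c(NCc4ccccn4)cc(C)nc23)cc1`: < 5000 nM

In a physicochemical assay for solubility, read by HPLC, using the shake flask method, measured as kinetic solubility, with a stated time of 2 h, at pH 7.4 (on this read-out higher numbers stand for higher solubility and lower numbers for lower solubility), compound 1 gives 7100 nM. Compound 2 gives only a limit in this assay, < 5000 nM. Compound 3 also gives only a limit in this assay, < 5000 nM. Compound 3 thus sits at the limit of < 5000 nM in this assay, at which 2 of the 3 values shown sit, so its own number is not known. For the measured compounds named here, the one step measured, a step that the two limits leave unreadable from compound 2 to compound 3, is unreadable and carries no information on a ring swap.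

Compound 4 `Cc1cc(NCc2ccccn2)n2ncc(-c3ccsc3)c2n1` differs from compound 3 in this way: thiophen-3-yl in place of 4-methoxyphenyl on an aromatic carbon. Going by the values given here, no measured step covers this change, so the expectation for compound 4 rests on the spread of the values shown. Compound 4 is estimated at 5000 nM, between 1500 nM and 15000 nM. The expected step from compound 3 is a number no lower from compound 3 to compound 4 (the limit leaves the size open), with the chance that compound 4 also returns only a limit judged high.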

Compound 4, solubility: 9000 nM
Beside the measured number, compound 4's estimate is 1.8-fold (0.26 log units) below it; measured number inside the range.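

In this assay, for the compounds shown here, thiophen-3-yl in place of 4-methoxyphenyl on this aromatic carbon gives an at least 1.8-fold higher number from compound 3 to compound 4 (0.25 log units; that floor lies within the scatter) and is the first readable step. This position therefore tolerates a ring change that lifts the read-out clear of the assay limit. As far as these compounds go, the true size of the step stays open, since only a floor can be read: the limit of < 5000 nM in this assay, at which 2 of the 4 values shown sit.

Still open, from the compounds shown here alone, is how an amine or a carboxylic acid on this aromatic carbon would read. Also open, going by these compounds, is whether the step would hold with methyl in place of hydrogen on the neighbouring core position, as in compound 2.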